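Swapping chloro for amino on a shared two-ring core

The compounds below may be only part of what the source reports. "The series", "measured", "known", "first", "only" and "open" are said of these compounds alone.

Of the compounds shown here, three built on one two-ring core have been tested in a functional assay on IGROV-1 cells (Homo sapiens) for cytotoxicity, read by sulforhodamine B assay, with a stated time of 48 h; on this read-out higher numbers stand for lower toxicity in this test and lower numbers for higher toxicity in this test. Compound 3 `ClCc1ccc(Cn2cnc3c(Cl)nc(Cl)nc32)cc1` gives 60300 nM. Compound 1 `Nc1nc(Cl)c2ncn(Cc3ccc(CCl)cc3)c2n1` differs from it in a single place, (amino in place of chloro on an aromatic carbon), and in this assay compound 1 gives 53700 nM. That change produced a 1.1-fold lower number from compound 3 to compound 1 (0.05 log units; within the scatter). Compound 2 `ClCc1cccc(Cn2cnc3c(Cl)nc(Cl)nc32)c1` is made of the same atoms as compound 3, joined differently; the difference between the two cores is not broken down here. In this assay compound 2 gives 20000 nM, the lowest of the three numbers. Compound 4 `Nc1nc(Cl)c2ncn(Cc3cccc(CCl)c3)c2n1` is not yet measured. It stands to compound 2 as compound 1 stands to compound 3, through (amino in place of chloro on an aromatic carbon), the same change at the same surroundings. With no other guide than that earlier pair, the expectation is that the second swap behaves like the first. Because a 1.1-fold lower number from compound 3 to compound 1 (0.05 log units; within the scatter) was a small step, the step expected for compound 4 is a 1.1-fold lower number from compound 2 to compound 4 (0.05 log units; within the scatter). Compound 4 is therefore estimated at 18000 nM. The estimate for compound 4 is expected to run from 9000 nM to 40000 nM.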

Compound 4, concentration lethal to 50% of the cells: 55000 nM
Compound 4: the middle estimate sits 3.1-fold (0.49 log units) below what was measured; the measured number lies above the stated range.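

In this assay, amino in place of chloro on the core of compound 2 brought a 2.8-fold higher number from compound 2 to compound 4 (0.44 log units; beyond the scatter), which on this read-out stands for lower toxicity in this test. Set beside the earlier pair, the change did not carry over from one core to the other with the same size: the same change on two cores in this assay, a 1.1-fold lower number (0.05 log units; within the scatter) from compound 3 to compound 1 and a 2.8-fold higher number (0.44 log units; beyond the scatter) from compound 2 to compound 4, 3.1-fold (0.49 log units) apart, beyond the scatter of two such steps. Among these compounds, this shows that, for these two cores made of the same atoms joined differently, a step measured on one was a poor guide to the step on the other, but with only two pairs it does not show why they differ or what the change would do on any further core.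

The compounds shown carry only chloro or amino on the aromatic carbon between two ring nitrogen atoms. On these data alone, whether a methoxy group or a dimethylamino group at that carbon would also give a step that differs between the two cores remains open.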